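Swapping the Methoxypyridine Ring for a Methoxymethylphenyl Ring

This account rests on a few compounds, and the source may have more. Where it says the series, first, only, none or still open, it means among the compounds named here.

Compound 2 `COc1ccc(-c2ccc(OCc3cc(C(=O)NS(=O)(=O)c4c(C)noc4C)oc3C)cc2)nc1` is the reference point. In an assay on cells for displacement of a labelled ligand from prostaglandin E2 receptor EP4 subtype (Homo sapiens), read by scintillation counting (a lower number here means a stronger inhibitor, a higher number a weaker inhibitor), compound 2 gives 13 nM, the lowest of the two numbers recorded. Compound 3 `CC(C)c1oc(C(=O)O)cc1COc1ccc(-c2ccccc2)cc1` gives 3000 nM, a far higher number, and that gap lies beyond the scatter. Compound 1 `Cc1oc(C(=O)O)cc1COc1ccc(-c2nnco2)cc1` sits at the limit of > 10000 nM in this assay, at which 1 of the 3 values shown sits; its entry of > 10000 nM is a limit of the assay, not a number.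

Compound 4 `COc1ccc(-c2ccc(OCc3cc(C(=O)NS(=O)(=O)c4c(C)noc4C)oc3C)cc2)c(C)c1` has not yet been measured. It differs from compound 2 in one place: 4-methoxy-2-methylphenyl in place of 5-methoxypyridin-2-yl on an aromatic carbon. Within the data shown here, no measured pair tracks a change of this kind, so the expectation rests on compound 2 alone. The step of a 1.5-fold higher number from compound 2 to compound 4 (0.19 log units; within the scatter) is expected to stay within the usual scatter. Compound 4 is therefore estimated at 20 nM, in a range from 5 nM to 80 nM.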

Compound 4, inhibition constant: 24 nM
Compound 4: the middle estimate sits 1.2-fold (0.08 log units) below what was measured, within the range that was stated.
By their numbers in this assay, from the lowest: compounds 2 and 4 (each within the scatter of the next); then compound 3. At a limit, above all of these: compound 1.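

With a 1.8-fold higher number from compound 2 to compound 4 (0.27 log units; within the scatter), the two compounds cannot be told apart in this assay. At this position, a ring of carbon only, 4-methoxy-2-methylphenyl, can therefore stand in place of 5-methoxypyridin-2-yl, so the ring nitrogen is not required for a value in this range. No measurement shown here gives a reason for this result.

Going by these compounds, the methyl group arrives together with the loss of the ring nitrogen, so the contribution of each remains unknown. Also open, on these data alone, is how a ring carrying an amine or a fluorine atom in place of the methyl group would behave.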